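Swapping 3,5-difluorophenyl for 4-methoxyphenyl on an oxygen

A few compounds are considered here, and "the series" means these few. Any claim that something is new, unique, unknown or untested is made for them only; others in the source may bear on it.

Measured so far in a functional assay on HT-29 cells (Homo sapiens) for antiproliferative activity, read by sulforhodamine B assay, with a stated time of 48 h (on this read-out lower numbers stand for stronger inhibition and higher numbers for weaker inhibition), for three compounds:
- compound 1 `COc1ccc(OS(=O)(=O)c2ccc(N3CCN(C)C3=O)cc2)cc1` gives > 100000 nM (a limit)
- compound 2 `CCCCN1CCN(c2ccc(S(=O)(=O)Oc3ccc(OC)c(OC)c3)cc2)C1=O` gives 21000 nM (a number)
- compound 3 `CCCCN1CCN(c2ccc(S(=O)(=O)Oc3cc(F)cc(F)c3)cc2)C1=O` gives > 100000 nM (a limit)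

Compound 3 stands at a limit of this assay and has no true number. This ceiling is no rare case, with the limit of > 100000 nM in this assay, at which 2 of the 3 values shown sit, in this small set. Compound 4 `CCCCN1CCN(c2ccc(S(=O)(=O)Oc3ccc(OC)cc3)cc2)C1=O` carries 4-methoxyphenyl in place of 3,5-difluorophenyl on an oxygen and keeps the rest of compound 3 unchanged. Within the data shown here, the one measured step that bears on this is an at least 4.7-fold higher number from compound 2 to compound 3 (0.67 log units; beyond the scatter) and it brought in the same 3,5-difluorophenyl, so removing that group may give a lower number. Its size is only a minimum. A caution comes from compound 1, which has the 4-methoxyphenyl and a methyl instead of the butyl, yet gives only a limit of > 100000 nM in this series. A modest move to a lower number is expected, namely an at least 2.5-fold lower number from compound 3 to compound 4 (0.39 log units; beyond the scatter) as an estimate, and the limit may still be reported. For compound 4 the estimated value is 40000 nM with an expected range of 12000 nM to 100000 nM.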

Compound 4, half-maximal inhibitory concentration: 35000 nM
The estimate for compound 4 lay 1.1-fold (0.06 log units) above the measured number; low and high end bracket the measured number.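

In this assay, 4-methoxyphenyl on the oxygen bound to the sulfonyl sulfur restores a measurable number, with an at least 2.8-fold lower number from compound 3 to compound 4 (0.45 log units; beyond the scatter), so the loss seen with 3,5-difluorophenyl does not apply to every group at this place. Taking away the second methoxy gives a 1.7-fold higher number from compound 2 to compound 4 (0.22 log units; within the scatter), so one methoxy serves here as well as two. Butyl in place of methyl on the amide-type nitrogen in a ring also counts, with an at least 2.8-fold lower number from compound 1 to compound 4 (0.45 log units; beyond the scatter), and this size, like the first, is only a minimum because one end of each step sits at the ceiling: the limit of > 100000 nM in this assay, at which 2 of the 4 values shown sit.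

From the compounds shown here alone, how far the numbers would move with an amine or a carboxylic acid in place of the methoxy remains open. So does whether a chain longer than butyl would give a lower number still.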